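Moving the hydroxyl on the phenyl group: working notes

This account rests on a few compounds, and the source may have more. Where it says the series, first, only, none or still open, it means among the compounds named here.

Measured in an ADME assay on a cell-free system (plasma, Rattus norvegicus) for metabolic stability, read by LC-MS, with a stated time of 1 h, tested at 100 uM; a higher number here means that more of the compound is left, a lower number that less of the compound is left:
- compound 1 `CC1=C(c2nc(-c3ccc(C#N)cc3)cs2)C(c2ccc(F)nc2)NC(=O)N1`: 100%
- compound 2 `CC1=C(c2nc(-c3ccc(C#N)cc3)cs2)C(c2cccc(O)c2)NC(=O)N1`: 88.5%

In this assay compound 2 gives 88.5%, the lower of the two numbers. Next is compound 3 `CC1=C(c2nc(-c3ccc(C#N)cc3)cs2)C(c2ccc(O)cc2)NC(=O)N1`, with the change 4-hydroxyphenyl in place of 3-hydroxyphenyl on a saturated ring carbon. Going by the values given here, the only measured step that bears on it is a number 11.5 percentage points lower from compound 1 to compound 2 (beyond the scatter), a modest one that exchanges a different group on that carbon. Among the compounds with values here, no measured step compares the two hydroxyphenyl groups, so the evidence is thin. The expected change is a number 1.5 percentage points higher from compound 2 to compound 3 (within the scatter), with no step beyond the scatter expected. For compound 3 the estimated value is 90%, with an expected range of 77% to 100%.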

Compound 3, percent of the compound remaining: 100%
Compound 3: the middle estimate sits 10 percentage points below what was measured, and the stated range covers the measured number.
By their numbers in this assay, from the lowest: compound 2; then compounds 1 and 3 (each within the scatter of the next).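

In this assay, moving the hydroxyl gives a number 11.5 percentage points higher from compound 2 to compound 3 (beyond the scatter), so 3-hydroxyphenyl and 4-hydroxyphenyl are not interchangeable on this saturated ring carbon, although their counted atoms match. Replacing 6-fluoropyridin-3-yl with 4-hydroxyphenyl gives no change at the digits printed from compound 1 to compound 3 (within the scatter), so these two groups cannot be told apart in this read-out. Nothing available explains the difference between the two hydroxyphenyl groups. 

The compounds shown leave open how a methoxyphenyl or an aminophenyl group on this carbon would compare. They also leave open whether a plain phenyl group would match 4-hydroxyphenyl or 3-hydroxyphenyl.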